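This account rests on a few compounds, and the source may have more. Where it says the series, first, only, none or still open, it means among the compounds named here.

In a functional assay on A549 cells (Homo sapiens) for antiproliferative activity, read by MTT assay, with a stated time of 48 h (on this read-out lower numbers stand for stronger inhibition and higher numbers for weaker inhibition), compound 3 `CCOc1ccc(C(=O)/C=C/c2c(/C=C/c3ccc(OC)cc3)cc(OC)cc2OC)cc1` gives 7.5 ug/mL and sits within the scatter of compound 1 `COc1ccc(/C=C/c2cc(OC)cc(OC)c2/C=C/C(=O)c2ccc(Cl)c(Cl)c2)cc1` at 5.9 ug/mL and of compound 2 `COc1ccc(/C=C/c2cc(OC)cc(OC)c2/C=C/C(=O)c2ccc(N)cc2)cc1` at 3.8 ug/mL on this read-out. Compound 4 `COc1ccc(/C=C/c2cc(OC)cc(OC)c2/C=C/C(=O)c2ccc(C)cc2C)cc1` keeps the shared core but carries 2,4-dimethylphenyl in place of 4-ethoxyphenyl on a carbonyl carbon. Three measured steps changed the group at that same place, namely a 1.6-fold lower number from compound 1 to compound 2 (0.19 log units; within the scatter) and a 1.3-fold higher number from compound 1 to compound 3 (0.10 log units; within the scatter) and a 2.0-fold higher number from compound 2 to compound 3 (0.30 log units; within the scatter) and each stayed within the scatter. For the measured compounds named here, no measured compound carries 2,4-dimethylphenyl, so the expectation rests on those steps alone, and no step beyond the scatter is expected in this assay for this swap. The estimate amounts to a 1.3-fold lower number from compound 3 to compound 4 (0.10 log units; within the scatter) as an expected change. Compound 4 is expected at 6 ug/mL with a range from 2.5 ug/mL to 14 ug/mL in this estimate.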

Compound 4, half-maximal inhibitory concentration: 0.3 ug/mL
For compound 4 the middle estimate is 20-fold (1.30 log units) above the measured one, and the stated range ends above it.
By their numbers in this assay, from the lowest: compound 4; then compounds 2, 1 and 3 (each within the scatter of the next).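

In this assay, for the compounds shown here, the group on the carbonyl carbon proves able to move the number far, which the earlier compounds never showed, as their steps stayed within the scatter. Placing 2,4-dimethylphenyl there gives a large step against each earlier group (a 25-fold lower number from compound 3 to compound 4 (1.40 log units; beyond the scatter)) and (a 13-fold lower number from compound 2 to compound 4 (1.10 log units; beyond the scatter)) and (a 20-fold lower number from compound 1 to compound 4 (1.29 log units; beyond the scatter)).

On these data alone, whether both methyl groups are needed stays open, as does how a phenyl carrying a single methyl, or ethyl groups in place of the methyls, would compare. No evidence here accounts for the large gain.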